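A few compounds are considered here, and "the series" means these few. Any claim that something is new, unique, unknown or untested is made for them only; others in the source may bear on it.

In an assay on Sf9 cells for inhibition of serine/threonine-protein kinase 4 (Homo sapiens), read by luminescence and ADP-Glo, with a stated time of 1 h, in the presence of a further agent that is not named here (a higher number here means a weaker inhibitor, a lower number a stronger inhibitor), compound 1 `CCC1C(=O)N(C)c2cnc(Nc3ccc(S(N)(=O)=O)cc3)nc2N1C` gives 479 nM. For the measured compounds named here, compound 2 `CC(C)C1C(=O)N(C)c2cnc(Nc3ccc(S(N)(=O)=O)cc3)nc2N1C` gives 254 nM in this assay and stands at the lowest of the two numbers so far, yet the step of a 1.9-fold lower number from compound 1 to compound 2 (0.28 log units; within the scatter) lies within the scatter, so the two cannot be told apart. Compound 3 `CN1C(=O)C(CC2CC2)N(C)c2nc(Nc3ccc(S(N)(=O)=O)cc3)ncc21` differs from compound 2 by cyclopropylmethyl in place of isopropyl on a saturated ring carbon. Going by the values given here, the only step that bears on this change is that earlier one, which also enlarged the group on this carbon and stayed within the scatter, so nothing beyond the scatter is expected. The expected step is a 1.0-fold higher number from compound 2 to compound 3 (0.01 log units; within the scatter). Compound 3 is estimated at 260 nM in this assay, between 110 nM and 620 nM.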

Compound 3, half-maximal inhibitory concentration: 211 nM
Beside the measured number, compound 3's estimate is 1.2-fold (0.09 log units) above it, within the range that was stated.
By their numbers in this assay, from the lowest: compounds 3, 2 and 1 (each within the scatter of the next, the first and the last beyond it).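

On this saturated ring carbon, a three-membered ring can enter as cyclopropylmethyl in place of isopropyl, yet compound 2 and compound 3 cannot be told apart (a 1.2-fold lower number from compound 2 to compound 3 (0.08 log units; within the scatter)). For the compounds shown here, the wider comparison gives the first step here beyond the scatter, though a modest one, with cyclopropyl in place of methyl on the saturated chain carbon (a 2.3-fold lower number from compound 1 to compound 3 (0.36 log units; beyond the scatter)). No evidence is available to explain either result. From the compounds shown here alone, whether this carbon would also accept an amine, a carboxylic acid or a longer chain remains open.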